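This account rests on a few compounds, and the source may have more. Where it says the series, first, only, none or still open, it means among the compounds named here.

So far, two compounds have been measured in an ADME assay on BJ cells (Homo sapiens) for cytotoxicity, read by MTT assay, with a stated time of 72 h; a higher number here means that more compound is tolerated, a lower number that less compound is tolerated. Compound 1 `OC[C@H]1O[C@@H](n2cc(F)c3c(-c4ccoc4)ncnc32)[C@H](O)[C@@H]1O` gives 350 nM, and compound 2 `OC[C@H]1O[C@@H](n2cc(F)c3c(-c4cccs4)ncnc32)[C@H](O)[C@@H]1O` gives 170 nM, the lower of the two numbers. They share a core and differ only in one five-membered aromatic ring attached to it. That exchange produced a 2.1-fold lower number from compound 1 to compound 2 (0.31 log units; beyond the scatter), a modest step that lies just beyond the usual scatter of repeat measurements.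

Compound 3 `OC[C@H]1O[C@@H](n2cc(F)c3c(-c4ccc[nH]4)ncnc32)[C@H](O)[C@@H]1O` changes the same group once more: 1H-pyrrol-2-yl in place of thiophen-2-yl on an aromatic carbon. Here, 1H-pyrrol-2-yl takes the place of thiophen-2-yl on an aromatic carbon. Among the compounds with values here, only one measured step bears on this swap, so it offers a rough guide to size and little guide to direction. It does suggest that exchanging one such ring for another need not move the number far. Within the data shown here, compound 1, at 350 nM, is the only comparison available for compound 2, so a small rise is the more likely outcome, though this is a weak basis. The expected change is a 1.5-fold higher number from compound 2 to compound 3 (0.17 log units; within the scatter), similar in size to the measured step. For compound 3, the estimated value is 250 nM, with an expected range from 90 nM to 700 nM.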

Compound 3, half-maximal cytotoxic concentration: 2990 nM
Estimate against measurement, compound 3: 12-fold (1.08 log units) below, outside the stated range (above it).
By their numbers in this assay, from the lowest: compound 2; then compound 1; then compound 3.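

At this position, on an aromatic carbon next to the ring nitrogen, the earlier pair suggested that exchanging one five-membered aromatic ring for another moves the number only a little, but 1H-pyrrol-2-yl breaks that impression in this assay: the change gives an 18-fold higher number from compound 2 to compound 3 (1.25 log units; beyond the scatter), a large step, and an 8.5-fold higher number from compound 1 to compound 3 (0.93 log units; beyond the scatter), a modest one. Both steps lie beyond the scatter and run in the direction of more compound being tolerated, so the identity of the ring matters here far more than the first step showed. Thiophen-2-yl and 1H-pyrrol-2-yl have the same number of heavy atoms and one hetero atom each, differing in nitrogen for sulfur and in their counts of hydrogen-bond donors and acceptors, but nothing available explains why this exchange has so large an effect.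

On these data alone, it remains open whether the hydrogen on the pyrrole nitrogen matters, which a 1H-pyrrol-2-yl analogue with a methyl group on that nitrogen could help to test. As far as these compounds go, it is also open how an amine or a carboxylic acid at this position would compare with these rings.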